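Carboxy to hydroxymethyl on compound 2

The source may hold more compounds than are shown below. What is called first, only, known or untested is meant among the compounds shown, and "the series" means these compounds.

- compound 1 `Cc1coc(-c2ccc3c(c2O)CCCC3)c1C(=O)O`: 29.4 uM
- compound 2 `COc1c(-c2occ(C)c2C(=O)O)ccc2c1CCCC2(C)C`: 47.8 uM

Both values come from a functional assay on KBVIN cells (Homo sapiens) for cytotoxicity, read by sulforhodamine B assay, with a stated time of 3 days; a higher number here means that more compound is needed for the effect, a lower number that less compound is needed. Compound 2 gives 47.8 uM and compound 1 gives 29.4 uM; these two numbers lie within the usual scatter of each other, so they mark a single level and no order. The next compound to be measured is compound 3 `COc1c(-c2occ(C)c2CO)ccc2c1CCCC2(C)C`, which differs from compound 2 in one place: hydroxymethyl in place of carboxy on an aromatic carbon. Hydroxymethyl stands in place of carboxy on an aromatic carbon.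

Within the data shown here, no measured pair shows this exchange, and no measured compound carries hydroxymethyl, so the expectation rests on little. In this assay a small move toward a lower number is expected, but not one clearly beyond the scatter. The expected size is the estimated step of a 1.6-fold lower number from compound 2 to compound 3 (0.20 log units; within the scatter). Among the measured compounds shown here, the range stays wide because the only direct reference is compound 2 at 47.8 uM. The estimate for compound 3 is 30 uM, with an expected range from 12 uM to 70 uM.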

Compound 3, concentration for half-maximal effect: 21.7 uM
For compound 3 the middle estimate is 1.4-fold (0.14 log units) above the measured one; the measured number falls inside the stated range.
By their numbers in this assay, from the lowest: compounds 3, 1 and 2 (each within the scatter of the next, the first and the last beyond it).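

Among these compounds, the earlier compounds all carried carboxy on the five-membered aromatic ring with 1 oxygen, so they gave no reading on this position; in this assay the exchange to hydroxymethyl now gives a 2.2-fold lower number from compound 2 to compound 3 (0.34 log units; beyond the scatter), the first step beyond the scatter. The step is modest and rests on a single pair, but it shows that carboxy is not required at this place for cytotoxicity at this level, and that replacing it with hydroxymethyl, a group with the same count of hydrogen-bond donors and acceptors, moves the number down rather than up. Among the compounds shown here, nothing measured so far accounts for the size or direction of this step.

The compounds shown leave open whether an amide, a methyl ester or a longer chain such as hydroxyethyl at this position would move the number further, or whether a simple methyl group would do as well. They also leave open whether the same exchange gives a comparable step on the core of compound 1, which differs from compound 2 in more than one place.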